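Notes on the step from compound 3 to compound 4

The source may report more compounds than this note shows. Statements on the series, on what has been measured and on what is new or still open speak of the compounds shown alone.

Measured so far in a functional assay on A549 cells (Homo sapiens) for antiproliferative activity, read by MTT assay, with a stated time of 48 h (a lower number here means a stronger inhibitor, a higher number a weaker inhibitor), on this series:
compound 1 `COc1ccc(/C=C/c2cc(OC)cc(OC)c2/C=C/C(=O)c2cccc(OC)c2)cc1` gives 6.1 ug/mL
compound 2 `CCCC(C)Oc1ccc(C(=O)/C=C/c2c(/C=C/c3ccc(OC)cc3)cc(OC)cc2OC)cc1` gives 9.4 ug/mL
compound 3 `COc1ccc(/C=C/c2cc(OC)cc(OC)c2/C=C/C(=O)c2cccc(Br)c2)cc1` gives 8.1 ug/mL

Compound 3 stands at 8.1 ug/mL on these numbers, within the scatter of both other compounds, so the three cannot be put in order. Next is compound 4 `COc1ccc(/C=C/c2cc(OC)cc(OC)c2/C=C/C(=O)c2cccc(Cl)c2)cc1`, and the change from compound 3 is chloro in place of bromo on an aromatic carbon in words chloro in place of bromo on an aromatic carbon, meta to a large group. The nearest measured change falls on an aromatic carbon too: a 1.3-fold higher number from compound 1 to compound 3 (0.12 log units; within the scatter) with bromo in place of methoxy, within the scatter. The larger exchanges on the carbonyl carbon, a 1.5-fold higher number from compound 1 to compound 2 (0.19 log units; within the scatter) and a 1.2-fold lower number from compound 2 to compound 3 (0.06 log units; within the scatter) also stay within the scatter. For the measured compounds named here, no measured compound carries chloro, so the data give no direct reading of this exchange. No step beyond the scatter is therefore expected in this assay and no direction is favoured. The estimate means an expected 1.1-fold lower number from compound 3 to compound 4 (0.03 log units; within the scatter) and nothing more should be read into its sign. Compound 4 is expected at 7.6 ug/mL (estimated range 4.6 ug/mL to 12 ug/mL).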

Compound 4, half-maximal inhibitory concentration: 5.6 ug/mL
Compound 4: the middle estimate sits 1.4-fold (0.13 log units) above what was measured; low and high end bracket the measured number.
By their numbers in this assay, from the lowest: compounds 4, 1, 3 and 2 (each within the scatter of the next).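

In this assay, the exchange of bromo for chloro on an aromatic carbon, meta to a large group, gives a step within the scatter (a 1.4-fold lower number from compound 3 to compound 4 (0.16 log units; within the scatter)), so this position now has a direct reading for a swap of one halogen for another. Taken with the step from methoxy (a 1.1-fold lower number from compound 1 to compound 4 (0.04 log units; within the scatter)), methoxy, bromo and chloro at this carbon cannot be told apart on these numbers. Even the exchange on the carbonyl carbon for the 4-(1-methylbutoxy)phenyl group, the largest step in the series so far (a 1.7-fold lower number from compound 2 to compound 4 (0.22 log units; within the scatter)), stays within the scatter, and nothing available speaks to the cause of any of these steps.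

Still open, as far as these compounds go, is whether any group at this carbon, such as an amine, a carboxylic acid or a nitrile, would move the number beyond the scatter. The rest of the core of compound 1 is the same in all four compounds, so these numbers say nothing about changes there.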